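A few compounds are considered here, and "the series" means these few. Any claim that something is new, unique, unknown or untested is made for them only; others in the source may bear on it.

Among the measured compounds shown here, compound 3 `CC(C)c1ccc(Nc2cccc3c2C(=O)N(C2CCC(=O)NC2=O)C3=O)cc1` gives 19% in an assay on FRT-Jurkat cells for inhibition of nuclear factor NF-kappa-B complex (Homo sapiens), read by flow cytometry, with a stated time of 24 h, tested at 10 uM (a higher number here means more inhibition at the concentration tested (going by the name of the read-out), a lower number less inhibition), the second highest of the three numbers so far: compound 1 `Cc1ccccc1Nc1cccc2c1C(=O)N(C1CCC(=O)NC1=O)C2=O` gives 7% and compound 2 `CC(C)(C)c1ccc(Nc2cccc3c2C(=O)N(C2CCC(=O)NC2=O)C3=O)cc1` gives 36%. Compound 4 `CCc1ccc(Nc2cccc3c2C(=O)N(C2CCC(=O)NC2=O)C3=O)cc1` differs from compound 3 by hydrogen in place of methyl on a saturated chain carbon bound to an aromatic carbon and a saturated chain carbon. For the measured compounds named here, the closest precedent is a number 17 percentage points lower from compound 2 to compound 3 (beyond the scatter), the same kind of change at the same place. The other steps, a number 29 percentage points higher from compound 1 to compound 2 (beyond the scatter) and a number 12 percentage points higher from compound 1 to compound 3 (beyond the scatter), exchange the whole group on the nitrogen on an aromatic ring and bear less directly. A further downward step beyond the scatter is therefore expected, a number 10 percentage points lower from compound 3 to compound 4 (within the scatter). Compound 4 is estimated at 9%, within 0% to 22%.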

Compound 4, a percentage reported as inhibition, at one concentration (the size of the read-out at that concentration, not a potency): 17%
Compound 4: the middle estimate sits 8 percentage points below what was measured, and the stated range covers the measured number.
By their numbers in this assay, from the lowest: compounds 1, 4 and 3 (each within the scatter of the next, the first and the last beyond it); then compound 2.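

In this assay, cutting isopropyl to ethyl gives a number 2 percentage points lower from compound 3 to compound 4 (within the scatter), so this removal of a methyl does not repeat the earlier drop from tert-butyl to isopropyl, and 4-isopropylphenyl and 4-ethylphenyl cannot be told apart. Only tert-butyl stands apart here, with a number 19 percentage points lower from compound 2 to compound 4 (beyond the scatter), while a number 10 percentage points higher from compound 1 to compound 4 (within the scatter) leaves 4-ethylphenyl unseparated from 2-methylphenyl. No available data explain this dependence on the group. Still open, on these data alone, is whether a longer chain such as n-butyl, or an amine or a carboxylic acid, on that aromatic carbon would match compound 2.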